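This account rests on a few compounds, and the source may have more. Where it says the series, first, only, none or still open, it means among the compounds named here.

Measured in an ADME assay on microsomes from liver (Mus musculus) for metabolic stability, with a stated time of 10 min; a lower number here means that less of the compound is left, a higher number that more of the compound is left:
Compound 1 `C[C@]1(C(=O)N2CC[C@](c3ccc(C(F)(C(F)(F)F)C(F)(F)F)cc3)(S(=O)(=O)c3ccc(F)cc3)C2)CC[C@@H](C(=O)O)CC1`: 100%
Compound 2 `NC(=O)[C@H]1CC[C@H](C(=O)N2CC[C@](c3ccc(C(F)(C(F)(F)F)C(F)(F)F)cc3)(S(=O)(=O)c3ccc(F)cc3)C2)CC1`: 100%
Compound 3 `CS(=O)(=O)C1CCC(C(=O)N2CC[C@](c3ccc(C(F)(C(F)(F)F)C(F)(F)F)cc3)(S(=O)(=O)c3ccc(F)cc3)C2)CC1`: 69%; "not determined" (no result reported) (2 entries)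

Compound 2 gives 100% in this assay, level with its nearest neighbour. Within the data shown here, the only measured step reads no change at the digits printed from compound 1 to compound 2 (within the scatter), so it offers no sign of how far a new group might move the result. Compound 4 `O=C(N1CC[C@](c2ccc(C(F)(C(F)(F)F)C(F)(F)F)cc2)(S(=O)(=O)c2ccc(F)cc2)C1)C1(F)CCS(=O)(=O)CC1` carries 4-fluoro-1,1-dioxothian-4-yl in place of 4-carbamoylcyclohexyl on a carbonyl carbon. The closest guide is compound 3, which also has a sulfonyl group in this part of the molecule and gives 69%; "not determined" (no result reported) (2 entries). That guide is thin, since its record is the several entries of compound 3 in this assay, 69%; "not determined" (no result reported) (2 entries). A moderate fall is therefore expected, a number 15 percentage points lower from compound 2 to compound 4 (beyond the scatter). The estimate for compound 4 is 85%, with an expected range of 60% to 100%.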

Compound 4, percent of the compound remaining: 90%
For compound 4 the middle estimate is 5 percentage points below the measured one, within the range that was stated.
By their numbers in this assay, from the lowest: compounds 4, 1 and 2 (each within the scatter of the next).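

In this assay, the group on the carbonyl carbon can change a good deal with little effect: with 4-fluoro-1,1-dioxothian-4-yl the result reads a number 10 percentage points lower from compound 2 to compound 4 (within the scatter) and a number 10 percentage points lower from compound 1 to compound 4 (within the scatter). A high number here therefore requires neither the carboxylic acid of compound 1 nor the carbamoyl group of compound 2. The only other compound with a sulfonyl group in this part of the molecule has a thin record, compound 3: the several entries of compound 3 in this assay, 69%; "not determined" (no result reported) (2 entries)

The compounds shown leave open what the ring fluorine contributes, since no pair differs by it alone. They also leave open how an amine or a longer chain would fare on this carbonyl carbon.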